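Replacing sulfamoyl with (2-hydroxyethyl)amino on the shared core

A few compounds are considered here, and "the series" means these few. Any claim that something is new, unique, unknown or untested is made for them only; others in the source may bear on it.

For the measured compounds named here, compound 1 `NS(=O)(=O)c1ccc(S(=O)(=O)Nc2cccc3c(Cl)c[nH]c23)cn1` holds the lowest number of the two measured so far in a functional assay on HCT-116 cells (Homo sapiens) for inhibition, with a stated time of 72 h (a higher number here means a weaker inhibitor, a lower number a stronger inhibitor), where compound 1 gives 290 nM. The nearest neighbour, compound 2 `N#Cc1c[nH]c2c(NS(=O)(=O)c3ccc(N)nc3)cccc12`, gives 640 nM in this assay, a gap beyond the usual scatter. Going by the values given here, no single-change step between measured compounds is available. Compound 3 `O=S(=O)(Nc1cccc2c(Cl)c[nH]c12)c1ccc(NCCO)nc1` differs from compound 1 by (2-hydroxyethyl)amino in place of sulfamoyl on an aromatic carbon. Among the compounds with values here, with no measured step to lean on, a modest weakening is expected, the step from compound 1 to compound 3 estimated at a 1.7-fold higher number from compound 1 to compound 3 (0.24 log units; within the scatter). Compound 3 is expected near 500 nM, within 200 nM to 1500 nM.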

Compound 3, half-maximal inhibitory concentration: 650 nM
The estimate for compound 3 lay 1.3-fold (0.11 log units) below the measured number; low and high end bracket the measured number.
By their numbers in this assay, from the lowest: compound 1; then compounds 2 and 3 (each within the scatter of the next).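

For the compounds shown here, at this place, on an aromatic carbon next to the ring nitrogen, the first single-change step in this assay is a 2.2-fold higher number from compound 1 to compound 3 (0.35 log units; beyond the scatter), with (2-hydroxyethyl)amino in place of sulfamoyl. Sulfamoyl therefore gives the lower number of this pair, although the step is only modest. Nothing available explains the size of this step.

Open, on these data alone, is how a longer chain or a carboxylic acid at this place would compare with sulfamoyl. This single step also leaves open whether the same change would give a similar step on another core.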